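The source may report more compounds than this note shows. Statements on the series, on what has been measured and on what is new or still open speak of the compounds shown alone.

In an ADME assay on HepG2 cells (Homo sapiens) for cytotoxicity, read by CellTiter-Glo and resazurin assay, with a stated time of 72 h (on this read-out lower numbers stand for an effect already at smaller amounts and higher numbers for an effect only at larger amounts of compound), compound 1 `CC(C)N(Cc1cccc(OCCCCCC(=O)O)c1)C(=O)c1ccc(-c2cccc3ccccc23)cc1` gives > 26000 nM, which is a limit of the assay and not a number. Compound 2 `CC(C)N(Cc1cccc(OCCCCCC(=O)O)c1)C(=O)c1ccc(-c2ccoc2)cc1` gives > 26000 nM, again only a limit. Within the data shown here, compound 2 therefore has no exact place on the scale, and both compounds measured so far sit at the limit of > 26000 nM in this assay, at which 2 of the 2 values shown sit.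

The next compound, compound 3 `CC(C)N(Cc1cccc(OCCCCCC(=O)O)c1)C(=O)c1ccc(-c2ccco2)cc1`, has the same atoms as compound 2, joined differently: furan-2-yl in place of furan-3-yl on an aromatic carbon. In words, furan-2-yl stands in place of furan-3-yl on an aromatic carbon, para to a large group.

Among the measured compounds shown here, only one measured step bears on this change, and it has no readable size: a step that the two limits leave unreadable from compound 1 to compound 2. That step exchanged naphthalen-1-yl for furan-3-yl and still ended at a limit, so it gives no ground for expecting a shift when one furan replaces the other. The estimated step is a number no higher from compound 2 to compound 3 (the limit leaves the size open), which means none beyond the usual scatter, and the assay will most likely report only a limit again. For compound 3 the estimated value is 26000 nM, with an expected range from 14000 nM to 50000 nM.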

Compound 3, half-maximal effective concentration: > 26000 nM
Compound 3: a limit, no number; the forecaster's own chance of this, stated with the estimate: 85%; the middle value sits exactly at the limit.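

In this assay compound 3 gives > 26000 nM, which is a limit and not a number. No step among compound 1, compound 2 and compound 3 can be read, since all three end at the same limit: the limit of > 26000 nM in this assay, at which 3 of the 3 values shown sit.

The compounds shown leave open whether naphthalen-1-yl, furan-3-yl and furan-2-yl differ at all in this read-out.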